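The source may report more compounds than this note shows. Statements on the series, on what has been measured and on what is new or still open speak of the compounds shown alone.

Within the data shown here, compound 1 `COc1ccc(C2C(OC(C)=O)C(=O)N2c2cc(OC)c(OC)c(OC)c2)cc1` is one of two compounds measured in a functional assay on IMR-32 cells (Homo sapiens) for cytotoxicity; on this read-out lower numbers stand for stronger inhibition and higher numbers for weaker inhibition. In this assay compound 1 gives 251 nM, the highest of the two numbers. Compound 2 `COc1ccc(C2C(O)C(=O)N2c2cc(OC)c(OC)c(OC)c2)cc1` differs from it by a hydrogen in place of acetyl on an oxygen on a saturated carbon; in this assay compound 2 gives 33 nM, which amounts to a 7.6-fold lower number from compound 1 to compound 2 (0.88 log units; beyond the scatter). Compound 3 `COc1ccc(C2C(OC(C)=O)C(=O)N2c2cc(OC)c(OC)c(OC)c2)cc1N` has not yet been measured. It differs from compound 1 in one place: amino in place of hydrogen on an aromatic carbon. The amino group enters on an aromatic carbon of a six-membered aromatic ring of carbon only, ortho to a methoxy group and meta to a large group; read one bond further out, 4-methoxyphenyl becomes 3-amino-4-methoxyphenyl. Among the measured compounds shown here, the only measured step, from compound 1 to compound 2, changes a different part of the molecule, the oxygen on the saturated carbon, and so carries no information about an amino group on the ring. For the measured compounds named here, with no comparable step available, the number in this assay for compound 3 is expected to stay close to that of compound 1, and the estimate for compound 3 is 250 nM, between 80 nM and 800 nM. The expected step is therefore a 1.0-fold lower number from compound 1 to compound 3 (0.00 log units; within the scatter), within the scatter.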

Compound 3, half-maximal inhibitory concentration: 73.1 nM
Beside the measured number, compound 3's estimate is 3.4-fold (0.53 log units) above it; the measured number lies below the stated range.
By their numbers in this assay, from the lowest: compound 2; then compound 3; then compound 1.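

In this assay, the place on the 4-methoxyphenyl group that carries only hydrogen in compound 1 turns out to matter: changing that group to 3-amino-4-methoxyphenyl gives a 3.4-fold lower number from compound 1 to compound 3 (0.54 log units; beyond the scatter). This shows that a part of the molecule away from the acetyl-bearing oxygen can also shift the number towards stronger inhibition, and that a single amino group on an aromatic carbon is enough to do so. Nothing measured here explains why the number moves.

The compounds shown do not tell whether the amino group is special at this place, or whether a hydroxyl group, a methyl group or an acetamide on the same aromatic carbon would give a similar number. They also leave open what happens when the two changes are combined, that is, whether the amino group gives a step of similar size on compound 2, which has hydrogen in place of acetyl on its oxygen.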